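This account rests on a few compounds, and the source may have more. Where it says the series, first, only, none or still open, it means among the compounds named here.

Measured so far in a functional assay on L1210 cells (Mus musculus) for inhibition; on this read-out higher numbers stand for weaker inhibition and lower numbers for stronger inhibition:
- compound 1, `CCNC(=O)c1ccc2[nH]c(NC(=O)OC)nc2c1`, gives 10000 nM
- compound 2, `CCCOC(=O)c1ccc2[nH]c(NC(=O)OC)nc2c1`, gives 7400 nM
- compound 3, `COC(=O)Nc1nc2cc(C(=O)OCCC(C)C)ccc2[nH]1`, gives 10000 nM

Compound 3 stands level with compound 1 at the digits shown, the two together giving the highest numbers of the three, and its nearest neighbour after that is compound 2 with a 1.4-fold higher number from compound 2 to compound 3 (0.13 log units; within the scatter). The change to compound 4, `COC(=O)Nc1nc2cc(C(=O)OCC3CC3)ccc2[nH]1`, is cyclopropyl in place of isobutyl on a saturated chain carbon bound to an oxygen next to a carbonyl group. Among the compounds with values here, the steps that bear on it are all alterations of the ester alkyl chain: a 1.4-fold lower number from compound 1 to compound 2 (0.13 log units; within the scatter), no change at the digits printed from compound 1 to compound 3 (within the scatter) and a 1.4-fold higher number from compound 2 to compound 3 (0.13 log units; within the scatter), each within the scatter. No step beyond the scatter in this assay is therefore expected for compound 4, and its estimate is 9000 nM, in the range 4500 nM to 20000 nM, meaning a 1.1-fold lower number from compound 3 to compound 4 (0.05 log units; within the scatter).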

Compound 4, half-maximal inhibitory concentration: 6900 nM
Beside the measured number, compound 4's estimate is 1.3-fold (0.12 log units) above it; the measured number falls inside the stated range.
By their numbers in this assay, from the lowest: compounds 4, 2, 1 and 3 (each within the scatter of the next).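

In this assay cyclopropyl in place of isobutyl gives a 1.4-fold lower number from compound 3 to compound 4 (0.16 log units; within the scatter) and cyclopropyl in place of ethyl gives a 1.1-fold lower number from compound 2 to compound 4 (0.03 log units; within the scatter) while cyclopropylmethoxy in place of ethylamino gives a 1.4-fold lower number from compound 1 to compound 4 (0.16 log units; within the scatter) on the same read-out. A three-membered ring at this place, the first ring on this chain among the compounds shown, thus leaves compound 4 within the scatter of all three others. Nothing at hand bears on the reason for this. From the compounds shown here alone, whether a carboxylic acid, an amine or a longer chain at this place would give a step beyond the scatter stays open.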